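The source may hold more compounds than are shown below. What is called first, only, known or untested is meant among the compounds shown, and "the series" means these compounds.

Measured so far in an assay on isolated protein for displacement of a labelled ligand from Gonadotropin-releasing hormone receptor (Rattus norvegicus); on this read-out higher numbers stand for weaker inhibition and lower numbers for stronger inhibition:
compound 1 `CCc1nc(C)c(CN2CCN(c3cccc4[nH]c(-c5ccc(C(C)(C)C)cc5)nc34)CC2)s1` gives 120 nM
compound 2 `CCCn1cnc(CN2CCN(c3cccc4[nH]c(-c5ccc(C(C)(C)C)cc5)nc34)CC2)c1C` gives 47 nM
compound 3 `CCCCn1cnc(CN2CCN(c3cccc4[nH]c(-c5ccc(C(C)(C)C)cc5)nc34)CC2)c1C` gives 49 nM

For the measured compounds named here, compound 3 stands second highest of the three numbers; its nearest neighbour is compound 2, within the scatter, and the only step beyond the scatter from it is a 2.4-fold lower number from compound 1 to compound 3 (0.39 log units; beyond the scatter). Compound 4 `CCCn1c(CC)nc(C)c1CN1CCN(c2cccc3[nH]c(-c4ccc(C(C)(C)C)cc4)nc23)CC1` differs from compound 3 by 2-ethyl-4-methyl-1-propyl-1H-imidazol-5-yl in place of 1-butyl-5-methyl-1H-imidazol-4-yl on a saturated chain carbon bound to an amine nitrogen in a ring. Bearing on this: a 1.0-fold higher number from compound 2 to compound 3 (0.02 log units; within the scatter) stays within the scatter, while a 2.6-fold lower number from compound 1 to compound 2 (0.41 log units; beyond the scatter) and a 2.4-fold lower number from compound 1 to compound 3 (0.39 log units; beyond the scatter) give a modest gain on exchanging the 2-ethyl-4-methyl-1,3-thiazol-5-yl for an imidazolyl. Adding an ethyl to the imidazolyl has no precedent here. The expectation is therefore no step beyond the scatter, a 1.1-fold higher number from compound 3 to compound 4 (0.05 log units; within the scatter). Compound 4 is estimated at 55 nM, range 22 nM to 140 nM.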

Compound 4, half-maximal inhibitory concentration: 120 nM
For compound 4 the middle estimate is 2.2-fold (0.34 log units) below the measured one, and the stated range covers the measured number.
By their numbers in this assay, from the lowest: compounds 2 and 3 (each within the scatter of the next); then compounds 1 and 4 (each within the scatter of the next).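

In this assay, the 2-ethyl-4-methyl-1-propyl-1H-imidazol-5-yl gives a weaker number than either earlier imidazolyl (a 2.4-fold higher number from compound 3 to compound 4 (0.39 log units; beyond the scatter); a 2.6-fold higher number from compound 2 to compound 4 (0.41 log units; beyond the scatter)), so the earlier gain over the thiazolyl does not extend to every imidazolyl on this saturated chain carbon. Against the 2-ethyl-4-methyl-1,3-thiazol-5-yl, the step stays within the scatter (no change at the digits printed from compound 1 to compound 4 (within the scatter)). No measurement here offers an explanation for these steps.

From the compounds shown here alone, the 2-ethyl and the shift from imidazol-4-yl to imidazol-5-yl arrive together, so their separate contributions stay open. Also open, going by these compounds, is how a terminal amine or carboxylic acid on the 1-propyl chain would read.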